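This account rests on a few compounds, and the source may have more. Where it says the series, first, only, none or still open, it means among the compounds named here.

In a functional assay on NCI-H1975 cells (Homo sapiens) for antiproliferative activity (on this read-out lower numbers stand for stronger inhibition and higher numbers for weaker inhibition), compound 1 (`COCCC(=O)N1CCc2c(C)c3c(n2-c2ccc(C(N)=O)c(c2)N[C@@H](C)[C@H](C)C1)CC(C)(C)CC3=O`) gives 31 nM and compound 2 (`Cc1c2c(n3c1CCN(C(=O)C(C)(C)N)C[C@@H](C)[C@H](C)Nc1cc-3ccc1C(N)=O)CC(C)(C)CC2=O`) gives 21 nM on the shared core. These two numbers lie within the usual scatter of each other, so compound 2 stands level with compound 1 on the data so far. Compound 3 (`Cc1c2c(n3c1CCN(C(=O)C1(N)CC1)C[C@@H](C)[C@H](C)Nc1cc-3ccc1C(N)=O)CC(C)(C)CC2=O`) alters compound 2 in one place: 1-aminocyclopropyl in place of 1-amino-1-methylethyl on a carbonyl carbon and so 1-aminocyclopropyl stands in place of 1-amino-1-methylethyl on a carbonyl carbon. Among the compounds with values here, only one measured step bears on this change. Within the data shown here, it is a 1.5-fold lower number from compound 1 to compound 2 (0.17 log units; within the scatter) and it concerns the group on a carbonyl carbon, though it is a different exchange from the one in compound 3. Among the measured compounds shown here, that single step stayed within the scatter, and no measured step yet tests 1-aminocyclopropyl itself, so the guidance is indirect. No change beyond the scatter is therefore expected, and the estimated step is a 1.1-fold lower number from compound 2 to compound 3 (0.02 log units; within the scatter) in this assay with no firm direction. Compound 3 is estimated at 20 nM with an expected range from 8 nM to 50 nM as its likely span.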

Compound 3, half-maximal inhibitory concentration: 72 nM
The estimate for compound 3 lay 3.6-fold (0.56 log units) below the measured number, and the stated range ends below it.
By their numbers in this assay, from the lowest: compounds 2 and 1 (each within the scatter of the next); then compound 3.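

Within the data shown here, the group on this carbonyl carbon proves less free to change in this assay than the first pair suggested: 1-aminocyclopropyl in place of 1-amino-1-methylethyl gives a 3.4-fold higher number from compound 2 to compound 3 (0.54 log units; beyond the scatter), and in place of 2-methoxyethyl it gives a 2.3-fold higher number from compound 1 to compound 3 (0.37 log units; beyond the scatter), so both steps to the new group lie beyond the scatter, whereas the one earlier step at this position stayed within it. The two groups exchanged between compound 2 and compound 3 match in heavy atoms, hydrogen-bond donors, hydrogen-bond acceptors and net charge, and what is counted differently is the three-membered non-aromatic ring of carbon only, which shows that even an exchange this small at this position can move the number beyond the scatter. No measurement offered here explains why the number rises with this exchange.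

What the compounds shown leave open is whether the rise belongs to the three-membered ring as such or would also appear with a 1-aminocyclobutyl or 1-aminocyclopentyl group on the same carbonyl carbon. They also leave open whether the amine on the group matters at all, which a plain cyclopropyl or a tert-butyl group in its place could test.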